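Reversed amide series: imidazolyl for trifluoromethyl on the anilide ring

This account rests on a few compounds, and the source may have more. Where it says the series, first, only, none or still open, it means among the compounds named here.

Compound 1 `Nc1n[nH]c2cccc(C#Cc3cccc(NC(=O)c4cc(C(F)(F)F)cc(C(F)(F)F)c4)c3)c12` and compound 3 `Nc1n[nH]c2cccc(C#Cc3cccc(C(=O)Nc4cc(C(F)(F)F)cc(C(F)(F)F)c4)c3)c12` are built from the same atoms joined differently; the difference between the two cores is not broken down here. Compound 2 `Cc1cn(-c2cc(C(=O)Nc3cccc(C#Cc4cccc5[nH]nc(N)c45)c3)cc(C(F)(F)F)c2)cn1` and compound 4 `Cc1cn(-c2cc(NC(=O)c3cccc(C#Cc4cccc5[nH]nc(N)c45)c3)cc(C(F)(F)F)c2)cn1` carry the same replacement on each core. In a functional assay on K562 cells (Homo sapiens) for inhibition, read by MTT assay, with a stated time of 72 h (on this read-out higher numbers stand for weaker inhibition of growth and lower numbers for stronger inhibition of growth), compound 1 gives > 10000 nM, which is a limit of the assay. Compound 2 gives 70 nM in this assay and compound 3 gives 520 nM. The change 4-methyl-1H-imidazol-1-yl in place of trifluoromethyl on an aromatic carbon made an at least 140-fold lower number from compound 1 to compound 2 (2.15 log units; beyond the scatter); the size of that step is bounded because compound 1 sits at the limit of > 10000 nM in this assay, at which 1 of the 3 values shown sits. The change 4-methyl-1H-imidazol-1-yl in place of trifluoromethyl on an aromatic carbon is the same change on the other core. From compound 3 to compound 4 in this assay a step of about a 26-fold lower number from compound 3 to compound 4 (1.41 log units; beyond the scatter) is expected, resting on compound 2 at 70 nM. Compound 4 is therefore estimated at 20 nM, between 4 nM and 120 nM.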

Compound 4, concentration for 50% growth inhibition: 150 nM
For compound 4 the middle estimate is 7.5-fold (0.88 log units) below the measured one; the whole stated range lies below it.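

In this assay, 4-methyl-1H-imidazol-1-yl in place of trifluoromethyl gives a 3.5-fold lower number from compound 3 to compound 4 (0.54 log units; beyond the scatter), so the direction of the change carries over between the two cores, but its size does not: the same change on two cores in this assay, an at least 140-fold lower number (2.15 log units; beyond the scatter) from compound 1 to compound 2 and a 3.5-fold lower number (0.54 log units; beyond the scatter) from compound 3 to compound 4, at least 41-fold (1.61 log units) apart, beyond the scatter of two such steps

Compound 1 stands at a limit of the assay, so the step from it is a bound and not a measured size: the limit of > 10000 nM in this assay, at which 1 of the 4 values shown sits.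

Two cores show no more than this, and they do not show how the change would read on a further core or why its size differs.

Open, as far as these compounds go, is whether the methyl group on the imidazole ring matters, as a plain 1H-imidazol-1-yl would show. Also open, from the compounds shown here alone, is how an amine such as 4-methylpiperazin-1-yl would read in place of trifluoromethyl on either core.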